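Nitro for Chloro on a Salicylanilide Anilide Ring

The source may report more compounds than this note shows. Statements on the series, on what has been measured and on what is new or still open speak of the compounds shown alone.

Of the compounds shown here, three that share a phenol-bearing amide core have been measured in a functional assay on Jurkat cells (Homo sapiens) for cytotoxicity, read by luminescence and CellTiter-Glo, with a stated time of 3 days; a higher number here means a weaker inhibitor, a lower number a stronger inhibitor. Compound 1 `O=C(Nc1ccc(C(F)(F)F)c(Cl)c1)c1cc(Cl)ccc1O` gives 690 nM. Compound 2 `O=C(Nc1ccc(C(F)(F)F)cc1)c1ccc2cccnc2c1O` gives 550 nM. Compound 3 `O=C(Nc1ccc(Cl)cc1Cl)c1cc(F)ccc1O` gives 880 nM. Compound 3 sits close to the other two: its gap to compound 1 and its gap to compound 2 both lie within the usual scatter, so the three numbers cannot be told apart with confidence.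

Compound 4 `O=C(Nc1ccc([N+](=O)[O-])cc1Cl)c1cc(F)ccc1O` has not yet been measured. It differs from compound 3 in one place: nitro in place of chloro on an aromatic carbon. For the measured compounds named here, no measured pair shows this change, so there is no direct guide to its effect.

On the spread of the three numbers, a step of modest size toward a lower number is expected, though one that may still fall inside the scatter. Compound 4 is therefore estimated at 500 nM, with a range from 200 nM to 1500 nM, which means an expected step of a 1.8-fold lower number from compound 3 to compound 4 (0.25 log units; within the scatter).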

Compound 4, half-maximal inhibitory concentration: 530 nM
For compound 4 the middle estimate is 1.1-fold (0.03 log units) below the measured one; the measured number falls inside the stated range.
By their numbers in this assay, from the lowest: compounds 4, 2, 1 and 3 (each within the scatter of the next).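

In this assay, the position meta to a chloro group and para to a large group takes a nitro group in place of chloro, a larger group that brings hydrogen-bond acceptors, and the result is a 1.7-fold lower number from compound 3 to compound 4 (0.22 log units; within the scatter). For the compounds shown here, this is the first comparison here between compounds that differ in one place, and it shows that this exchange leaves compound 3 and compound 4 within the scatter of each other, so they cannot be told apart in this assay. No measurement shown here offers an explanation for the size of this step.

On these data alone, whether an amine, a nitrile or a carboxylic acid at this position would give a step beyond the scatter remains open. A single pair also leaves open whether nitro in place of chloro would give a similar step at the other chloro group or on another core.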